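Naphthalenyl for phenyl on a hydrazone-bearing carbon: expected cost

The source may report more compounds than this note shows. Statements on the series, on what has been measured and on what is new or still open speak of the compounds shown alone.

Compound 1 `COc1ccc(C2CC(c3ccc4ccccc4c3)=NN2C2=NC(=O)/C(=C3\C(=O)Nc4ccccc43)S2)cc1`: 2470 nM
Compound 2 `O=C1N=C(N2N=C(c3ccccc3)CC2c2ccc(Cl)cc2)S/C1=C1/C(=O)Nc2ccccc21`: 850 nM

Of the compounds shown here, two have been measured in a functional assay on cells (Cancer cell lines, Homo sapiens) for cytotoxicity, read by sulforhodamine B assay, with a stated time of 48 h; on this read-out higher numbers stand for weaker inhibition of growth and lower numbers for stronger inhibition of growth. Compound 2 `O=C1N=C(N2N=C(c3ccccc3)CC2c2ccc(Cl)cc2)S/C1=C1/C(=O)Nc2ccccc21` gives 850 nM, the lower of the two numbers, and so the stronger growth inhibition. Compound 1 `COc1ccc(C2CC(c3ccc4ccccc4c3)=NN2C2=NC(=O)/C(=C3\C(=O)Nc4ccccc43)S2)cc1` gives 2470 nM, a higher number and a difference that lies beyond the usual scatter. Among the compounds with values here, compound 1 differs from compound 2 in two places at once, so the two values together show only that the pair does not behave alike; no single change can be read from them.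

Compound 3 `O=C1N=C(N2N=C(c3ccc4ccccc4c3)CC2c2ccc(Cl)cc2)S/C1=C1/C(=O)Nc2ccccc21` has not yet been measured. It differs from compound 2 by one change, (naphthalen-2-yl in place of phenyl on a carbon with a double bond to nitrogen), namely naphthalen-2-yl in place of phenyl on a carbon with a double bond to nitrogen. The 4-chlorophenyl group of compound 2 is kept.

Within the data shown here, with no measured step of this kind available, the account rests on the two values alone. Compound 1, which also carries naphthalen-2-yl at that carbon, gives the weaker result, and a moderate weakening is therefore expected from compound 2 to compound 3, a 1.6-fold higher number from compound 2 to compound 3 (0.22 log units; within the scatter), though a step within the scatter would not surprise. Compound 3 is estimated at 1400 nM in this assay, with a range from 500 nM to 4000 nM.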

Compound 3, concentration for total growth inhibition: 50700 nM
For compound 3 the middle estimate is 36-fold (1.56 log units) below the measured one; measured number outside the range, above it.
By their numbers in this assay, from the lowest: compound 2; then compound 1; then compound 3.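

In this assay, with the 4-chlorophenyl group kept, naphthalen-2-yl in place of phenyl on the carbon with a double bond to nitrogen gives a 60-fold higher number from compound 2 to compound 3 (1.78 log units; beyond the scatter) and so shows that this position responds strongly to the change, which the two earlier values could not isolate. With naphthalen-2-yl kept, chloro in place of methoxy on an aromatic carbon gives a 21-fold higher number from compound 1 to compound 3 (1.31 log units; beyond the scatter) and so shows that the outcome also depends on the group carried by the other aromatic ring. Compound 1 carries the same naphthalen-2-yl group as compound 3 yet gives the lower number of that pair, so naphthalen-2-yl alone does not set the value. Nothing given here explains either step.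

On these data alone, it remains open whether the large step from phenyl to naphthalen-2-yl would also appear with the 4-methoxyphenyl group in place of the 4-chlorophenyl group. As far as these compounds go, it is also open how a methyl group or a phenyl ring bearing an amine would behave on the carbon with a double bond to nitrogen.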